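Benzyl in Place of Butoxy on a Shared Core

The compounds below may be only part of what the source reports. "The series", "measured", "known", "first", "only" and "open" are said of these compounds alone.

Measured compounds:
compound 1, `COc1ccc(NC(=O)Nc2n[nH]c3ccccc23)cc1`, gives > 100000 nM
compound 2, `CCCCOc1ccc(NC(=O)n2nc(N)c3ccccc32)cc1`, gives 11300 nM
compound 3, `Nc1nn(C(=O)Nc2c(F)cccc2F)c2ccccc12`, gives 86200 nM

All three were tested in a functional assay on KM12 cells (Homo sapiens) for inhibition, read by sulforhodamine B assay, with a stated time of 48 h; on this read-out lower numbers stand for stronger inhibition of growth and higher numbers for weaker inhibition of growth. For compound 1 this assay reports only a limit, > 100000 nM, as noted in the limit of > 100000 nM in this assay, at which 1 of the 3 values shown sits. Of the two actual numbers, compound 2 gives the lowest, and compound 3 stands higher by a gap beyond the scatter.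

Compound 4, `Nc1nn(C(=O)Nc2ccc(Cc3ccccc3)cc2)c2ccccc12`, is not yet measured. It differs from compound 2 by benzyl in place of butoxy on an aromatic carbon. Among the measured compounds shown here, no measured pair shows such a change, so its size is uncertain; a step roughly within the scatter is expected, leaning toward a lower number. Compound 4 is thus estimated at 8000 nM, between 2000 nM and 40000 nM. The expected step is a 1.4-fold lower number from compound 2 to compound 4 (0.15 log units; within the scatter).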

Compound 4, concentration for 50% growth inhibition: 2940 nM
Compound 4: the middle estimate sits 2.7-fold (0.43 log units) above what was measured; measured number inside the range.
By their numbers in this assay, from the lowest: compound 4; then compound 2; then compound 3. At a limit, above all of these: compound 1.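

Benzyl in place of butoxy on an aromatic carbon, para to a large group, gives a 3.8-fold lower number from compound 2 to compound 4 (0.58 log units; beyond the scatter) in this assay and is the first step here between measured compounds that differ in one place. In this one pair, growth inhibition does not depend on keeping the oxygen of butoxy, and a group with a six-membered aromatic ring of carbon only is accepted at this position.

On these data alone, how an amine, a carboxylic acid or a longer carbon chain at this position would compare remains open. No measurement shown gives a reason for this step.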